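Adding chloro to compound 1: what to expect

The source may report more compounds than this note shows. Statements on the series, on what has been measured and on what is new or still open speak of the compounds shown alone.

Compound 1 `CC(=O)n1nc(NC(=O)c2ccccc2)c2c1CN(C(=O)c1ccccc1)C2` gives 580 nM
Compound 2 `CC(C)C(=O)n1nc(NC(=O)c2ccccc2)c2c1CN(C(=O)c1ccccc1)C2` gives 2020 nM

In a functional assay on HCT-116 cells (Homo sapiens) for cytotoxicity, read by sulforhodamine B assay, with a stated time of 48 h (on this read-out lower numbers stand for stronger inhibition and higher numbers for weaker inhibition), lower numbers mean stronger inhibition, and compound 1, at 580 nM, holds the lower of the two numbers. Compound 3 `CC(=O)n1nc(NC(=O)c2ccccc2)c2c1CN(C(=O)c1cccc(Cl)c1)C2` has not been measured yet. It differs from compound 1 by one change: chloro in place of hydrogen on an aromatic carbon. This places chloro in place of hydrogen on an aromatic carbon, meta to a large group. For the measured compounds named here, only one measured step exists, a 3.5-fold higher number from compound 1 to compound 2 (0.54 log units; beyond the scatter). That step put isopropyl in place of methyl on a carbonyl carbon, so it involves neither chloro nor an aromatic carbon and gives little guidance here. With no measured change at the aromatic carbon, no step beyond the scatter is expected in this assay. The estimated step is a 1.2-fold lower number from compound 1 to compound 3 (0.06 log units; within the scatter). For compound 3 the expected value is 500 nM, with an estimated range of 170 nM to 1500 nM.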

Compound 3, half-maximal inhibitory concentration: 17400 nM
The estimate for compound 3 lay 35-fold (1.54 log units) below the measured number; measured number outside the range, above it.
By their numbers in this assay, from the lowest: compound 1; then compound 2; then compound 3.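

In this assay, chloro in place of hydrogen on an aromatic carbon, meta to a large group, gives a 30-fold higher number from compound 1 to compound 3 (1.48 log units; beyond the scatter) and so turns the benzoyl of compound 1 into a (3-chlorophenyl)carbonyl. This shows that the benzoyl ring is not a place where any change passes unnoticed: a single added heavy atom moves the number further than the change on the carbonyl carbon, which gave a 3.5-fold higher number from compound 1 to compound 2 (0.54 log units; beyond the scatter) as a modest step. No measurement shown here gives a reason for this large step.

Going by these compounds, whether the same aromatic carbon would behave differently with fluoro, methoxy or an amine remains open. Also open, on these data alone, is whether chloro elsewhere on this ring would give a step of similar size.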